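Shortening the side chain of an alkynoate ester

The source may report more compounds than this note shows. Statements on the series, on what has been measured and on what is new or still open speak of the compounds shown alone.

Compound 1: `CCCCCCC(C#CC(=O)O)O/C=C/C(=O)OC` gives > 100000 nM in a functional assay on SW1573 cells (Homo sapiens) for antiproliferative activity, read by sulforhodamine B assay, with a stated time of 48 h (a lower number here means a stronger inhibitor of growth, a higher number a weaker inhibitor of growth), a limit of the assay.
Compound 2: `CCCCCCC(C#CC(=O)OC)O/C=C/C(=O)OC` gives 3300 nM in this assay.
Compound 3: `CCOC(=O)C#CCO/C=C/C(=O)OC` gives 1800 nM in this assay.

Compound 4, `COC(=O)C#CC(C)O/C=C/C(=O)OC`, has not yet been measured in this assay. It differs from compound 2 by hydrogen in place of pentyl on a saturated chain carbon, two bonds along the chain from an oxygen on an unsaturated carbon and a triple-bonded carbon. Among the numbers shown, compound 2 and compound 3 lie within the scatter of each other, so no order between them can be drawn. The value of compound 1 is a limit, (the limit of > 100000 nM in this assay, at which 1 of the 3 values shown sits). Among the compounds with values here, the only step between measured compounds is an at least 30-fold lower number from compound 1 to compound 2 (1.48 log units; beyond the scatter), a change at a different part of the molecule, and it does not touch the carbon where compound 4 differs from compound 2. Compound 3 carries hydrogen at the corresponding chain carbon, but it also differs from compound 2 elsewhere, so its value cannot be read as a step for this change alone. Within the data shown here, no measured step therefore bears directly on the pentyl-to-hydrogen change, and the expected step is a 1.1-fold higher number from compound 2 to compound 4 (0.03 log units; within the scatter), not beyond the scatter. Compound 4 is expected to give 3500 nM, within 900 nM to 14000 nM, in this assay.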

Compound 4, concentration for 50% growth inhibition: 1700 nM
Compound 4: middle estimate off by 2.1-fold (0.31 log units), on the high side; the range from low to high includes it.
By their numbers in this assay, from the lowest: compounds 4, 3 and 2 (each within the scatter of the next). At a limit, above all of these: compound 1.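

Replacing pentyl with hydrogen on the saturated chain carbon, two bonds along the chain from an oxygen on an unsaturated carbon and a triple-bonded carbon, gives a 1.9-fold lower number from compound 2 to compound 4 (0.29 log units; within the scatter) in this assay, the first step shown at this carbon. Cutting hexyl to methyl here therefore leaves the growth inhibition within the scatter, so the long chain of compound 2 is not needed for the effect it shows in this assay. Nothing shown here gives a cause for this result.

On these data alone, whether a longer chain, a phenyl ring or an amine on this carbon would give a step beyond the scatter remains open. Also open, as far as these compounds go, is whether a carboxylic acid in place of the methyl ester of compound 4 would give a step as large as the one seen on the hexyl-bearing compounds.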